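Enlarging the Substituent on the Saturated Ring Carbon

The source may hold more compounds than are shown below. What is called first, only, known or untested is meant among the compounds shown, and "the series" means these compounds.

Two measured compounds share one core and differ only in the group attached to a saturated ring carbon. Compound 1 `CC1(c2ccc(-c3ccc4ccccc4c3)[nH]c2=O)OC(=O)NC1=O` carries a methyl there, and in a functional assay on CHO cells for antagonist activity at prostaglandin E2 receptor EP3 subtype (Homo sapiens), read by FLIPR, with a stated time of 1 h (a higher number here means a weaker inhibitor, a lower number a stronger inhibitor), compound 1 gives 20 nM. Compound 2 `O=C1NC(=O)C(c2ccc(-c3ccc4ccccc4c3)[nH]c2=O)(C2CC2)O1` carries a cyclopropyl in the same place, and in this assay compound 2 gives 50.1 nM. Within the data shown here, of the two numbers measured so far, compound 2 stands highest; the step of a 2.5-fold higher number from compound 1 to compound 2 (0.40 log units; beyond the scatter) lies beyond the scatter, so compound 2 is the weaker inhibitor of the pair.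

Compound 3 `O=C1NC(=O)C(c2ccc(-c3ccc4ccccc4c3)[nH]c2=O)(C2CCCCC2)O1` has not yet been measured. The change from compound 2 is cyclohexyl in place of cyclopropyl on a saturated ring carbon. Among the measured compounds shown here, only one measured step bears on it, the replacement of methyl by cyclopropyl, a 2.5-fold higher number from compound 1 to compound 2 (0.40 log units; beyond the scatter), which weakened inhibition by a modest amount. Enlarging the group further at the same place is therefore expected to move in the same direction, again modestly, though this expectation rests on a single comparison. For compound 3 in this assay the expected value is 150 nM, within a range from 50 nM to 500 nM. This corresponds to an expected 3.0-fold higher number from compound 2 to compound 3 (0.48 log units; beyond the scatter).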

Compound 3, inhibition constant: 7.94 nM
Compound 3: the middle estimate sits 19-fold (1.28 log units) above what was measured; the measured number lies below the stated range.
By their numbers in this assay, from the lowest: compound 3; then compound 1; then compound 2.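

In this assay, replacing the cyclopropyl with a cyclohexyl on this saturated ring carbon gives a 6.3-fold lower number from compound 2 to compound 3 (0.80 log units; beyond the scatter), which more than reverses the loss seen with cyclopropyl, and replacing the methyl with a cyclohexyl gives a 2.5-fold lower number from compound 1 to compound 3 (0.40 log units; beyond the scatter). Compound 3 is therefore the strongest inhibitor of the three, and this position is not one where a larger group simply means a weaker inhibitor: the numbers rise from methyl to cyclopropyl and then fall from cyclopropyl to cyclohexyl, and compound 2 goes against any steady trend in favour of larger groups. Nothing available here accounts for this turn in the series, so the numbers record the change without explaining it.

The compounds shown leave open whether the gain belongs to a saturated carbon ring of this particular size, since a cyclobutyl or cyclopentyl group would fill the gap between the two rings, and a phenyl ring or an open chain such as hexyl would test whether a ring is needed at all. They also leave open how this position responds to a cyclohexyl carrying a hydroxyl or an amine.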